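The source may report more compounds than this note shows. Statements on the series, on what has been measured and on what is new or still open speak of the compounds shown alone.

Compound 1 `CCCc1ncc2cnnc(S)n12`: > 48000 nM, a limit of the assay rather than a number.
Compound 2 `CCCc1nc(C)c2c(C)nnc(SC)n12`: > 48000 nM, again a limit.
Compound 3 `CCCc1nnc(SC)n2c(CCC)nc(C)c12`: > 48000 nM, also a limit.

All three compounds were tested in a functional assay for inhibition, with Homo sapiens as the target (on this read-out lower numbers stand for stronger inhibition and higher numbers for weaker inhibition), and every value sits at the limit of > 48000 nM in this assay, at which 3 of the 3 values shown sit. Within the data shown here, none of the three is a measured number, so no compound can be ranked against another here.

Compound 2 and compound 3 differ in one place: hydrogen in place of ethyl on a saturated chain carbon bound to an aromatic carbon. The step that the two limits leave unreadable from compound 3 to compound 2 cannot be read, as both of its ends sit at the limit of > 48000 nM in this assay, at which 3 of the 3 values shown sit.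

Compound 4 `Cc1ncc2cnnc(S)n12` has not yet been measured in this assay. It differs from compound 1 by hydrogen in place of ethyl on a saturated chain carbon bound to an aromatic carbon. Among the measured compounds shown here, this is the same change as the one from compound 3 to compound 2, made at the same place in the same words. How the core of compound 1 differs from the core of compound 3 is not broken down here; the two differ in more than one place.

For the measured compounds named here, the expectation for compound 4 rests on compound 1 standing at the limit of > 48000 nM in this assay, at which 3 of the 3 values shown sit, and on the one measured example of this change, the step that the two limits leave unreadable from compound 3 to compound 2, giving no readable size. Compound 4 is therefore expected to give 100000 nM, within a range from 40000 nM to 400000 nM, and most likely to be reported only as a limit. The step this estimate means is a step that the limit leaves unreadable from compound 1 to compound 4.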

Compound 4, half-maximal inhibitory concentration: > 48000 nM
Compound 4: a limit, no number (the forecaster's own chance of this, stated with the estimate: 85%); the middle value is on the limit's open side.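

No new step can be read between compound 1 and compound 4, because both results are limits of the assay rather than numbers, so the change from propyl to methyl has no readable size: the limit of > 48000 nM in this assay, at which 4 of the 4 values shown sit.

The compounds shown leave open whether this change has any effect in this assay, and which structures, if any, would give a measured number there.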